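The source may hold more compounds than are shown below. What is called first, only, known or untested is meant among the compounds shown, and "the series" means these compounds.

Compound 2 `O=C(CN1CCC(c2cccc[n+]2[O-])CC1)Nc1ccc(F)cc1F` stands highest of the three numbers shown in a functional assay on HEK293 cells for agonist activity at D(4) dopamine receptor (Homo sapiens), read by FLIPR (a lower number here means a smaller maximal response, a higher number a larger maximal response), though only within the scatter: compound 2 gives 74%, while compound 1 `O=C(CN1CCC(c2cccc[n+]2[O-])CC1)Nc1cccc(F)c1` gives 70% and compound 3 `Cc1cccc(C)c1NC(=O)CN1CCC(c2cccc[n+]2[O-])CC1` gives 68%. Compound 4 `O=C(CN1CCC(c2cccc[n+]2[O-])CC1)Nc1ccc(F)cc1C(F)(F)F` differs from compound 2 by trifluoromethyl in place of fluoro on an aromatic carbon. Among the measured compounds shown here, no measured step exchanges exactly these two groups, but all three measured steps alter the group on the amide-type nitrogen, and each stayed within the scatter: a number 4 percentage points higher from compound 1 to compound 2 (within the scatter), a number 2 percentage points lower from compound 1 to compound 3 (within the scatter) and a number 6 percentage points lower from compound 2 to compound 3 (within the scatter). On that basis a step of a number 2 percentage points lower from compound 2 to compound 4 (within the scatter) is expected, nothing beyond the scatter. Compound 4 is therefore estimated at 72%, with a range from 58% to 86%.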

Compound 4, largest response reached (reported as efficacy), in percent of the reference or control that the assay uses: 65%
Compound 4: middle estimate off by 7 percentage points, on the high side; low and high end bracket the measured number.
By their numbers in this assay, from the lowest: compounds 4, 3, 1 and 2 (each within the scatter of the next).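

In this assay, trifluoromethyl in place of fluoro on an aromatic carbon, ortho to a large group, gives a number 9 percentage points lower from compound 2 to compound 4 (within the scatter). Unlike the earlier steps, which exchange the whole group on the amide-type nitrogen, this one alters a single substituent, and going from one heavy atom to four at this place does not move the maximal response beyond the scatter. Nothing available explains the size of this step. Still open, going by these compounds, is whether an amine or a carboxylic acid on this carbon would also stay within the scatter of compound 2.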